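A few compounds are considered here, and "the series" means these few. Any claim that something is new, unique, unknown or untested is made for them only; others in the source may bear on it.

Measured in an ADME assay on L6 cells (Rattus norvegicus) for cytotoxicity, read by fluorescence and resazurin assay, with a stated time of 72 h (a higher number here means that more compound is tolerated, a lower number that less compound is tolerated), so far:
- compound 1 `Cc1ccc(-c2c[nH]cc2C(c2ccc(Cl)cc2Cl)n2ccnc2)cc1` gives 18400 nM
- compound 2 `Clc1ccc(C(c2c[nH]cc2-c2ccc(Cl)cc2-n2cccc2)n2ccnc2)c(Cl)c1` gives 7670 nM
- compound 3 `Clc1ccc(C(c2c[nH]cc2-c2ccc(Cl)cc2-c2ccccc2)n2ccnc2)c(Cl)c1` gives 14300 nM

Compound 1 and compound 3 lie within the scatter of each other, while compound 2 lies lower than compound 1 by more than the scatter. Compound 4 `CS(=O)(=O)c1ccc(-c2c[nH]cc2C(c2ccc(Cl)cc2Cl)n2ccnc2)cc1` carries methylsulfonyl in place of methyl on an aromatic carbon, para to a large group: methylsulfonyl in place of methyl on an aromatic carbon. Among the measured compounds shown here, no measured step exchanges either of these groups. The only one available, a 1.9-fold higher number from compound 2 to compound 3 (0.27 log units; within the scatter), concerns other groups and stays small, so it gives only weak guidance. The expected change is a 1.1-fold higher number from compound 1 to compound 4 (0.04 log units; within the scatter) in this assay, which means no step beyond the scatter. Compound 4 is estimated at 20000 nM, with an expected range of 8000 nM to 50000 nM.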

Compound 4, half-maximal cytotoxic concentration: 68000 nM
Compound 4: middle estimate off by 3.4-fold (0.53 log units), on the low side, and the stated range ends below it.
By their numbers in this assay, from the lowest: compounds 2, 3 and 1 (each within the scatter of the next, the first and the last beyond it); then compound 4.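

Notes on the aromatic carbon para to a large group: in this assay, this position responds to substitution, with methylsulfonyl in place of methyl giving a rise beyond the scatter (a 3.7-fold higher number from compound 1 to compound 4 (0.57 log units; beyond the scatter)). Among the compounds shown here, the only earlier step, on a different group, stayed within the scatter, so this is the first exchange with a readable effect, and it points towards more compound tolerated. No available data explain the rise.

From the compounds shown here alone, it remains open whether this rise is specific to methylsulfonyl. A carboxylic acid, an amine or a nitrile at the same place could show whether other groups give a similar step.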